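The compounds below may be only part of what the source reports. "The series", "measured", "known", "first", "only" and "open" are said of these compounds alone.

Measured so far:
- compound 1 `COC(=O)c1ccc(/C=C/C(=O)c2cc3cc(O)ccc3oc2=O)cc1` gives 7100 nM in a functional assay on MOLT-4 cells (Homo sapiens) for cytotoxicity, read by MTT assay, with a stated time of 72 h; a higher number here means a weaker inhibitor, a lower number a stronger inhibitor
- compound 2 `COc1cccc(/C=C/C(=O)c2cc3cc(O)ccc3oc2=O)c1OC` gives 6700 nM in this assay

Compound 2 holds the lower of the two numbers, but compound 1 lies within the scatter of it, so the two cannot be told apart on these figures. The next compound, compound 3 `COc1cccc(/C=C/C(=O)c2cc3cc(OCc4ccccc4)ccc3oc2=O)c1OC`, is not yet measured. It differs from compound 2 in one place: benzyl in place of hydrogen on an oxygen on an aromatic ring, so the hydroxy on the shared core becomes a benzyloxy. Going by the values given here, no pair of measured compounds shows this change, so the direction rests on expectation alone. For this assay the step from compound 2 to compound 3 is expected to be small, with the number of compound 3 likely lowered a little, though a move within the scatter in either direction would not surprise, so compound 3 is estimated at 4500 nM, with a range from 1200 nM to 16000 nM and the expected step of a 1.5-fold lower number from compound 2 to compound 3 (0.17 log units; within the scatter).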

Compound 3, half-maximal inhibitory concentration: 23600 nM
The estimate for compound 3 lay 5.2-fold (0.72 log units) below the measured number, and the stated range ends below it.
By their numbers in this assay, from the lowest: compounds 2 and 1 (each within the scatter of the next); then compound 3.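

In this assay the oxygen on the shared core proves sensitive to what it carries: putting benzyl in place of its hydrogen gives a 3.5-fold higher number from compound 2 to compound 3 (0.55 log units; beyond the scatter) and so weakens the compound by a modest step beyond the scatter. Going by these compounds alone, this is the first change at this oxygen that can be read, and within this single pair the free hydroxy outperforms the benzyloxy. Nothing available explains why the number rises with this change.

The compounds shown leave open whether the step comes from losing the hydrogen or from the benzyl itself, a question that a methoxy at the same oxygen would help to settle. They also leave open whether a longer chain carrying an amine or a carboxylic acid on this oxygen would fare any better than benzyl.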